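This account rests on a few compounds, and the source may have more. Where it says the series, first, only, none or still open, it means among the compounds named here.

Measured so far:
Compound 1 `CC(C(=O)N1CCN(c2ccc(C(F)(F)F)cc2)CC1)N1C(=O)CCC1=O` gives 25% in a functional assay on the whole organism (strain Swiss) with Mus musculus as the target, in the maximal electroshock model, with a stated time of 0.5 h, at a dose of 300 mg/kg by the intraperitoneal route; a lower number here means a weaker effect, a higher number a stronger effect of the compound at the dose given.
Compound 2 `CC(C(=O)N1CCN(c2cccc(F)c2)CC1)N1C(=O)CCC1=O` gives 50% in this assay.
Compound 3 `CC(C(=O)N1CCN(c2ccccc2Cl)CC1)N1C(=O)CCC1=O` gives 0% in this assay.

Compound 3 stands lowest of the three numbers; compound 1 sits nearest to it and compound 2 furthest, both differences beyond the scatter. Compound 4 `CC(C(=O)N1CCN(c2ccccc2)CC1)N1C(=O)CCC1=O` differs from compound 3 by hydrogen in place of chloro on an aromatic carbon. Going by the values given here, the one measured step that bears on this position is a number 50 percentage points lower from compound 2 to compound 3 (beyond the scatter), the large drop that came with 2-chlorophenyl in place of 3-fluorophenyl. Compound 4 removes the chloro of compound 3 but lacks the fluoro of compound 2, so an upward step is expected, smaller than a full return to compound 2. Compound 4 is therefore expected to give 30%, between 0% and 60%, an expected step of a number 30 percentage points higher from compound 3 to compound 4 (beyond the scatter).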

Compound 4, a percentage reported as activity, at one dose (the size of the read-out at that dose, not a potency): 50%
Beside the measured number, compound 4's estimate is 20 percentage points below it; measured number inside the range.
By their numbers in this assay, from the lowest: compound 3; then compound 1; then compounds 2 and 4 (each within the scatter of the next).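

In this assay, hydrogen in place of chloro on this aromatic carbon alone accounts for a large change, a number 50 percentage points higher from compound 3 to compound 4 (beyond the scatter), so the earlier drop from compound 2 belongs with the chloro rather than with the loss of fluoro. Hydrogen and fluoro are not told apart, no change at the digits printed from compound 2 to compound 4 (within the scatter), whereas replacing trifluoromethyl with hydrogen gives a modest gain, a number 25 percentage points higher from compound 1 to compound 4 (beyond the scatter). No measured data on the series explain these steps. As far as these compounds go, whether the loss is specific to chloro remains open: bromo, methyl or methoxy in its place would test this.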